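Cyano in place of the ester on the side chain

The source may hold more compounds than are shown below. What is called first, only, known or untested is meant among the compounds shown, and "the series" means these compounds.

In a functional assay on U-373MG ATCC cells (Homo sapiens) for inhibition, read by MTT assay, with a stated time of 72 h (on this read-out higher numbers stand for weaker inhibition of growth and lower numbers for stronger inhibition of growth), compound 1 `CC1(C)CCC[C@]2(C)[C@@H](C=O)C(C=O)=CC[C@@H]12` reads > 100000 nM, which is a limit of the assay. Compound 2 `CCOC(=O)/C=C/C1=CC[C@H]2C(C)(C)CCC[C@]2(C)[C@H]1C=O` gives 37000 nM and compound 3 `CC(C)(C)OC(=O)/C=C/C1=CC[C@H]2C(C)(C)CCC[C@]2(C)[C@H]1C=O` gives 40000 nM, so compound 3 stands level with compound 2. Replacing formyl with the 2-(ethoxycarbonyl)ethenyl group gave an at least 2.7-fold lower number from compound 1 to compound 2 (0.43 log units; beyond the scatter). Exchanging ethyl for tert-butyl on the ester gave a 1.1-fold higher number from compound 2 to compound 3 (0.03 log units; within the scatter).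

Compound 4 `CC1(C)CCC[C@]2(C)[C@@H](C=O)C(/C=C/C#N)=CC[C@@H]12` differs from compound 3 as follows: cyano in place of tert-butoxycarbonyl on a double-bonded chain carbon bound to a double-bonded chain carbon. For the measured compounds named here, the only measured change within the ester, a 1.1-fold higher number from compound 2 to compound 3 (0.03 log units; within the scatter), suggests that no shift beyond the scatter should be expected, though no measured step tests cyano itself. The expected step is no change at the digits printed from compound 3 to compound 4 (within the scatter). For compound 4 the estimated value is 40000 nM, with an expected range of 15000 nM to 100000 nM.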

Compound 4, concentration for 50% growth inhibition: 36000 nM
Beside the measured number, compound 4's estimate is 1.1-fold (0.05 log units) above it; measured number inside the range.
By their numbers in this assay, from the lowest: compounds 4, 2 and 3 (each within the scatter of the next). At a limit, above all of these: compound 1.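

In this assay, the ester is not needed at this place on the chain: cyano in place of it gives a 1.1-fold lower number from compound 3 to compound 4 (0.05 log units; within the scatter) and a 1.0-fold lower number from compound 2 to compound 4 (0.01 log units; within the scatter), so the insensitivity seen between the two esters extends to a group that is no ester at all. The 2-cyanoethenyl group in place of formyl on a double-bonded ring carbon gives an at least 2.7-fold lower number from compound 1 to compound 4 (0.44 log units; beyond the scatter). That step is only a bound, as compound 1 stands at a limit: the limit of > 100000 nM in this assay, at which 1 of the 4 values shown sits.

As far as these compounds go, whether an amide, a carboxylic acid or an amine at the end of this chain would move the number beyond the scatter stays open. A longer chain between the ring and the cyano also remains untested in the compounds shown.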